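Adding a chain double bond to a stripped-down prostanoid analogue

A few compounds are considered here, and "the series" means these few. Any claim that something is new, unique, unknown or untested is made for them only; others in the source may bear on it.

Of the compounds shown here, three sharing one core have been tested in a functional assay on the whole organism (strain Hartley) for inhibition, with Cavia porcellus as the target, with stated times of 15 min and 2 min; a lower number here means that less compound is needed, a higher number that more compound is needed for the effect. Compound 1 `CCCC1([C@H](O)/C=C/C2[C@H](O)CC(=O)[C@@H]2C/C=C\CCCC(=O)O)CCC1` gives 0.003 mg/kg. Compound 2 `CCCCC1([C@@H](O)/C=C/C2[C@H](O)CC(=O)[C@@H]2CCCCCCC(=O)O)CCC1` gives 0.03 mg/kg. Compound 3 `CCCCC1([C@H](O)/C=C/C2CCC(=O)[C@@H]2CCCCCC(=O)O)CCC1`, which lacks the ring hydroxyl of the other two and carries a fully saturated acid chain, gives 0.32 mg/kg. Among these three numbers compound 3 stands highest: compound 2 sits at a lower number, compound 1 at a still lower one, and both of these gaps lie beyond the scatter of this assay.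

Compound 4 `CCCCC1([C@H](O)/C=C/C2CCC(=O)[C@@H]2C/C=C\CCCC(=O)O)CCC1` differs from compound 3 in one place. 5-carboxypent-1-en-1-yl in place of 4-carboxybutyl on a saturated chain carbon bound to a saturated ring carbon The entering chain carries one more carbon and one more double bond outside aromatic rings than the leaving one. For the measured compounds named here, compound 1, the only measured compound whose chain holds such a double bond, also has the lowest number of the three, so the change is expected to move the number downward by a step of a 5.3-fold lower number from compound 3 to compound 4 (0.73 log units; beyond the scatter), beyond the scatter. Compound 4 is therefore estimated at 0.06 mg/kg, within a range from 0.01 mg/kg to 0.3 mg/kg.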

Compound 4, dose for half-maximal effect: 0.0242 mg/kg
Compound 4: the middle estimate sits 2.5-fold (0.39 log units) above what was measured; the measured number falls inside the stated range.
By their numbers in this assay, from the lowest: compound 1; then compounds 4 and 2 (each within the scatter of the next); then compound 3.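

In this assay, 5-carboxypent-1-en-1-yl in place of 4-carboxybutyl on a saturated chain carbon bound to a saturated ring carbon gives a 13-fold lower number from compound 3 to compound 4 (1.12 log units; beyond the scatter), a large step and the first in this set that can be tied to a single place. Among the earlier compounds, no two differed in one place only, so their numbers could not show how much this chain alone matters, whereas here it accounts for the whole step, though the entering chain brings one more carbon and one more double bond together. Nothing measured here speaks to why the number moves.

The compounds shown do not separate the extra carbon from the double bond; a saturated 6-carboxyhexyl chain on the core of compound 3 would do so. As far as these compounds go, whether a methyl ester in place of the chain's carboxylic acid keeps the lower number also remains open.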